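This account rests on a few compounds, and the source may have more. Where it says the series, first, only, none or still open, it means among the compounds named here.

Measured compounds:
compound 1, `COc1cccc(S(=O)(=O)Nc2cccn(CC(=O)NCc3ccc4[nH]nc(N)c4c3)c2=O)c1` — 1930 nM
compound 2, `Cc1ccc(NS(=O)(=O)Cc2ccccc2)c(=O)n1CC(=O)NCc1ccc2[nH]ncc2c1` — 881 nM
compound 3, `Cc1ccc(NS(=O)(=O)Cc2ccc(Br)cc2)c(=O)n1CC(=O)NCc1ccc2c(N)noc2c1` — 2710 nM

These three compounds share a core and were tested in an in vivo ADME assay on the whole organism (plasma) for pharmacokinetics, with Canis familiaris (Canis lupus familiaris) as the target, at a dose of 1 mg/kg by the oral route; a lower number here means less compound in the circulation, a higher number more compound in the circulation at the dose given. Compound 2 stands lowest of the three numbers: compound 1 sits at a higher number, beyond the scatter, and compound 3 sits higher still, also beyond the scatter. No two of them differ in only one place, so none of these gaps can be tied to a single structural change.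

Compound 4, `Cc1ccc(NS(=O)(=O)Cc2ccccc2)c(=O)n1CC(=O)NCc1ccc2onc(N)c2c1`, has not yet been measured. It differs from compound 2 in one place: a group of 10 heavy atoms (7 carbon, 2 nitrogen, 1 oxygen; one five-membered aromatic ring with 2 hetero atoms, one six-membered aromatic ring of carbon only) in place of a group of 9 heavy atoms (7 carbon, 2 nitrogen; one five-membered aromatic ring with 2 hetero atoms, one six-membered aromatic ring of carbon only), on a saturated chain carbon bound to an amide-type nitrogen. The group that enters is the same group that compound 3 carries, and compound 3 shows the highest number of the three in this assay, though compound 3 also differs from compound 2 elsewhere.

On that basis a modest rise is expected from compound 2 to compound 4 in this assay, near the edge of the scatter, as a 1.7-fold higher number from compound 2 to compound 4 (0.23 log units; within the scatter). Compound 4 is therefore estimated at 1500 nM, within a range from 600 nM to 3500 nM.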

Compound 4, maximal plasma concentration: 498 nM
The estimate for compound 4 lay 3.0-fold (0.48 log units) above the measured number; the measured number lies below the stated range.
By their numbers in this assay, from the lowest: compounds 4 and 2 (each within the scatter of the next); then compounds 1 and 3 (each within the scatter of the next).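

Going by these compounds alone, this is the first comparison in the set where only one place changes, and it isolates the group on a saturated chain carbon bound to an amide-type nitrogen. In this assay, replacing 1H-indazol-5-yl with the larger ring group that also contains oxygen gives a 1.8-fold lower number from compound 2 to compound 4 (0.25 log units; within the scatter), so this exchange does not separate the two compounds, and this position tolerates the change without a clear shift in the read-out. No measurement shown accounts for this result.

This single step cannot show whether the same exchange would behave alike with a different remainder of the molecule. It also leaves open whether a simple phenyl ring bearing an amine or a carboxylic acid at this place would move the number beyond the scatter.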